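Capping the dihydroxyphenyl ether: from compound 1 to compound 4

The source may report more compounds than this note shows. Statements on the series, on what has been measured and on what is new or still open speak of the compounds shown alone.

Measured so far in a functional assay on HL-60 cells (Homo sapiens) for inhibition, read by CCK-8 assay, with a stated time of 48 h; on this read-out higher numbers stand for weaker inhibition and lower numbers for stronger inhibition:
compound 1 `CC(C)c1ccc(Oc2ccc(O)c(O)c2)c(-c2ccsc2S(=O)(=O)NCCNC(=S)Nc2cc(C(F)(F)F)cc(C(F)(F)F)c2)c1`: 8200 nM
compound 3 `COc1ccc(NC(=O)NCCNS(=O)(=O)c2ccc(-c3ccccc3Oc3ccc([N+](=O)[O-])c([N+](=O)[O-])c3)s2)cc1`: 5400 nM
compound 2 `O=S(=O)(NCCNC(=S)Nc1cc(C(F)(F)F)cc(C(F)(F)F)c1)c1ccc(-c2ccccc2OCc2cccc(O)c2)s1`: reported only as a limit, > 50000 nM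

Compound 1 holds the higher of the two numbers in this assay, with compound 3 at a gap that lies within the scatter, so the two cannot be ordered. The limit of compound 2 is one of the values sitting at the limit of > 50000 nM in this assay, at which 1 of the 3 values shown sits.

Compound 4 `COc1ccc(Oc2ccc(C(C)C)cc2-c2ccsc2S(=O)(=O)NCCNC(=S)Nc2cc(C(F)(F)F)cc(C(F)(F)F)c2)cc1OC` differs from compound 1 in one place: 3,4-dimethoxyphenyl in place of 3,4-dihydroxyphenyl on an oxygen on an aromatic ring. Among the measured compounds shown here, no step between measured compounds covers this change, so the direction rests on expectation alone. The estimated step from compound 1 to compound 4 is a 2.4-fold higher number from compound 1 to compound 4 (0.39 log units; beyond the scatter), toward weaker inhibition and beyond the scatter. Compound 4 is expected at 20000 nM, within 5000 nM to 50000 nM.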

Compound 4, half-maximal inhibitory concentration: 6900 nM
Compound 4: middle estimate off by 2.9-fold (0.46 log units), on the high side; measured number inside the range.
By their numbers in this assay, from the lowest: compounds 3, 4 and 1 (each within the scatter of the next). At a limit, above all of these: compound 2.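

In this assay, 3,4-dimethoxyphenyl in place of 3,4-dihydroxyphenyl gives a 1.2-fold lower number from compound 1 to compound 4 (0.07 log units; within the scatter), so this exchange on an oxygen on an aromatic ring leaves no readable change. The hydrogen-bond donors of the 3,4-dihydroxyphenyl can thus go without a measurable shift between these two compounds. Nothing shown bears on a cause for this.

Open, as far as these compounds go, is whether an amine or a carboxylic acid on this ring would move the number beyond the scatter. Also open, from the compounds shown here alone, is whether the same exchange holds on a different core.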